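From Phenacyl Ether to Aryl Carbamate on the Shared Core

The source may report more compounds than this note shows. Statements on the series, on what has been measured and on what is new or still open speak of the compounds shown alone.

Compound 3 `CC1(C)C=C(n2ccccc2=O)c2cc(OCC(=O)c3ccc(F)cc3)ccc2O1` gives 4.77 in a functional assay (trachea) with Rattus norvegicus as the target; a higher number here means a more potent compound, by a factor of ten per unit of this negative logarithm, a lower number a less potent compound. Among the three measured compounds it stands second highest: compound 2 `CC1(C)C=C(n2ccccc2=O)c2cc(OCC(=O)c3ccccc3)ccc2O1` gives 4.69, and the step of a number 0.08 log units higher from compound 2 to compound 3 (within the scatter) lies within the scatter. Compound 1 `Cc1ccccc1C(=O)c1ccc2c(c1)C(n1ccccc1=O)=CC(C)(C)O2`, which carries a different group on the shared core, gives 6.25, beyond the scatter above compound 3. Compound 4 `CC1(C)C=C(n2ccccc2=O)c2cc(OC(=O)Nc3ccc(F)cc3)ccc2O1` differs from compound 3 by (4-fluorophenyl)carbamoyl in place of ((4-fluorophenyl)carbonyl)methyl on an oxygen on an aromatic ring. Among the compounds with values here, no measured step bears directly on this exchange: the only step recorded, fluoro in place of hydrogen, is within the scatter and sits elsewhere on the molecule, and no measured pair separates a ((4-fluorophenyl)carbonyl)methyl group from a (4-fluorophenyl)carbamoyl group on the oxygen on the aromatic ring. The expectation therefore rests on the value of compound 3 alone, widened for an untested change. The step of a number 0.03 log units higher from compound 3 to compound 4 (within the scatter) is expected to stay within the scatter, in no firm direction. Compound 4 is estimated at 4.8, in a range from 4.1 to 5.6.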

Compound 4, logarithm of the reciprocal of the active concentration, log(1/C): 4.37
Beside the measured number, compound 4's estimate is 0.43 log units above it, within the range that was stated.
By their numbers in this assay, from the lowest: compound 4; then compounds 2 and 3 (each within the scatter of the next); then compound 1.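

In this assay, the exchange of ((4-fluorophenyl)carbonyl)methyl for (4-fluorophenyl)carbamoyl on an oxygen on an aromatic ring gives a number 0.40 log units lower from compound 3 to compound 4 (beyond the scatter), the first single change at this oxygen shown here to move the number beyond the scatter. The comparison with the unfluorinated phenacyl ether points the same way, with a number 0.32 log units lower from compound 2 to compound 4 (beyond the scatter), although that step also brings in the fluoro group, whose own step between compound 2 and compound 3 stayed within the scatter. The entering group matches the leaving one in heavy atoms but brings a nitrogen and a hydrogen-bond donor, and no evidence here accounts for the lower number.

As far as these compounds go, whether the lower number follows the amide hydrogen stays open, and a carbamate with a methyl group on its nitrogen would test this. From the compounds shown here alone, how a much smaller group on this oxygen, such as methyl, or a free hydroxyl would compare also remains unknown.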